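Swapping benzyl for dimethylphenyl on the cyanoguanidine nitrogen

The source may report more compounds than this note shows. Statements on the series, on what has been measured and on what is new or still open speak of the compounds shown alone.

Of the compounds shown here, three sharing one core have been tested in a functional assay (aorta) with Rattus norvegicus as the target; a lower number here means a stronger inhibitor, a higher number a weaker inhibitor. Compound 1 `CC1(C)Oc2ccc(C#N)cc2[C@@H](/N=C(\NC#N)NCc2ccccc2)[C@@H]1O` gives 2400 nM, the lowest number of the three. Compound 2 `CC1(C)Oc2ccc(C#N)cc2[C@@H](NC(=O)Nc2ccncc2)[C@@H]1O` gives 8500 nM, a gap from compound 1 that lies beyond the usual scatter, and compound 3 `CC1(C)Oc2ccc(C#N)cc2[C@@H](n2c(O)nc3ccccc32)[C@@H]1O` gives 41000 nM, a wider gap still. Compound 1 is therefore the strongest inhibitor among the measured compounds.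

Compound 4 `Cc1ccc(N/C(=N/[C@@H]2c3cc(C#N)ccc3OC(C)(C)[C@H]2O)NC#N)cc1C` has not yet been measured in this assay . It differs from compound 1 in one place: 3,4-dimethylphenyl in place of benzyl on an amine nitrogen. Going by the values given here, no measured pair shows this kind of change, so no step can be read off for it. The expectation rests only on compound 1 and the nature of the change, an aromatic ring brought one bond closer to the amine nitrogen and carrying two methyl groups. The step from compound 1 to compound 4 is expected to be small, within the scatter or slightly downward, as a 1.6-fold lower number from compound 1 to compound 4 (0.20 log units; within the scatter). Compound 4 is estimated at 1500 nM, with a likely range from 400 nM to 8000 nM.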

Compound 4, half-maximal inhibitory concentration: 5100 nM
For compound 4 the middle estimate is 3.4-fold (0.53 log units) below the measured one, within the range that was stated.
By their numbers in this assay, from the lowest: compound 1; then compounds 4 and 2 (each within the scatter of the next); then compound 3.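

Going by these compounds alone, this pair gives the first direct reading at this amine nitrogen: in this assay, placing 3,4-dimethylphenyl in place of benzyl gives a 2.1-fold higher number from compound 1 to compound 4 (0.33 log units; beyond the scatter), a modest loss of inhibition. The position therefore responds to the group it carries, yet the activity survives when the aromatic ring sits one bond closer to the nitrogen and bears two methyl groups. No supporting data accompany this result, so the pair records an outcome without explaining it.

The shorter link and the two methyl groups arrive together, so this single step cannot show how much each contributes. A plain phenyl group on the same nitrogen would help to separate them, while a longer chain such as phenethyl would test the opposite direction from benzyl.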